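The source may hold more compounds than are shown below. What is called first, only, known or untested is meant among the compounds shown, and "the series" means these compounds.

Two members of the series have been tested in a functional assay on HepG2 cells (Homo sapiens) for antiproliferative activity, read by MTT assay, with a stated time of 48 h; a higher number here means a weaker inhibitor, a lower number a stronger inhibitor. Compound 1 `N#CC1=C(N)Oc2c(c3nc4ccccc4nc3c3ccccc23)C12C(=O)N(Cc1cnnn1-c1ccc(Br)cc1)c1ccccc12` gives only a limit there, > 50000 nM. Compound 2 `Cc1ccc(C)c(-n2nncc2CN2C(=O)C3(C(C#N)=C(N)Oc4c3c3nc5ccccc5nc3c3ccccc43)c3ccccc32)c1` likewise gives only a limit, > 50000 nM. The step that the two limits leave unreadable from compound 1 to compound 2 is therefore not readable in size, both ends being limits. Compound 2 thus stands at the limit of this assay, and every value shown so far sits there: the limit of > 50000 nM in this assay, at which 2 of the 2 values shown sit.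

Compound 3 `Cc1ccc(-n2nncc2CN2C(=O)C3(C(C#N)=C(N)Oc4c3c3nc5ccccc5nc3c3ccccc43)c3ccccc32)c(C)c1` is not yet measured. It differs from compound 2 in one place: 2,4-dimethylphenyl in place of 2,5-dimethylphenyl on an aromatic nitrogen. Within the data shown here, the only measured step that touches this position is the one already named, from the 4-bromophenyl to the 2,5-dimethylphenyl on the aromatic nitrogen, and its size cannot be read from the two limits. Among the measured compounds shown here, no measured step therefore points to any change beyond the scatter in this assay, in either direction. The step that the limit leaves unreadable from compound 2 to compound 3 is accordingly expected to be none beyond the scatter. Compound 3 is expected to give 80000 nM in this assay, within 30000 nM to 300000 nM, most probably again reported only as a limit.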

Compound 3, half-maximal inhibitory concentration: > 50000 nM
Compound 3: a limit, no number; the forecaster's own chance of this, stated with the estimate: 85%; the middle value is on the limit's open side.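

In this assay compound 3 gives > 50000 nM as a limit, not a number. Among these compounds, compound 1, compound 2 and compound 3 all sit at a limit, and no step between them can be read. Still open, going by these compounds, is whether any group on this aromatic nitrogen, or any change to the shared core, gives a readable value in this assay at all.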